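The source may hold more compounds than are shown below. What is called first, only, known or untested is meant among the compounds shown, and "the series" means these compounds.

Measured in a physicochemical assay for lipophilicity, using the shake flask method, in phosphate buffer, measured as octanol-water partition, with a stated time of 1 h, at pH 7.4; on this read-out lower numbers stand for lower lipophilicity and higher numbers for higher lipophilicity:
- Compound 1 `CCNC(=O)Nc1cc(-c2nc(C(F)(F)F)cs2)c(-c2nc3cccc(C(=O)O)c3s2)cn1`: 0.73
- Compound 2 `CCNC(=O)Nc1cc(Br)c(-c2cncc(C(=O)O)c2)cn1`: -1
- Compound 3 `CCNC(=O)Nc1cc(-c2nc(C(F)(F)F)cs2)c(-c2cncc(-c3c(C)noc3C)c2)cn1`: 3.5

Compound 2 has the lowest of these three numbers, and compound 1 and compound 3 both stand above it by more than the scatter. Compound 4 `CCNC(=O)Nc1cc(-c2cccnc2)c(-c2cncc(C(=O)O)c2)cn1` differs from compound 2 in one place: pyridin-3-yl in place of bromo on an aromatic carbon. Here pyridin-3-yl replaces bromo on an aromatic carbon. Among the compounds with values here, compound 1 and compound 3 differ from compound 2 in more than one place, so no measured pair isolates this swap. In this assay, the expectation is therefore a small downward step, probably not beyond the scatter. The estimated change is a number 0.20 log units lower from compound 2 to compound 4 (within the scatter). The expected value for compound 4 is -1.2, within an estimated range of -1.8 to -0.5.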

Compound 4, distribution coefficient: -1.5
Estimate against measurement, compound 4: 0.30 log units above, within the range that was stated.
By their numbers in this assay, from the lowest: compound 4; then compound 2; then compound 1; then compound 3.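

In this assay, within the data shown here, a number 0.50 log units lower from compound 2 to compound 4 (beyond the scatter) is the only step that isolates a change at this position, on the aromatic carbon opposite the ring nitrogen. It shows that pyridin-3-yl, with 6 heavy atoms and a hydrogen-bond acceptor, does not raise the number here even though it replaces a single bromine. Nothing measured here gives a reason for this step. On these data alone, whether a plain phenyl ring or an amine at this carbon would move the number the same way remains open, as does whether the step would hold with a different group in place of the carboxylic acid.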